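Compound 4: a 4-aminophenyl in place of a 3-aminophenyl

A few compounds are considered here, and "the series" means these few. Any claim that something is new, unique, unknown or untested is made for them only; others in the source may bear on it.

Of the compounds shown here, three have been measured in a functional assay on L1210 cells (Mus musculus) for cytotoxicity, read by cell counting, with a stated time of 2 days; a higher number here means a weaker inhibitor, a lower number a stronger inhibitor. Compound 1 `Nc1cccc(/C=C2\SC(=O)N(Cc3cccc(Cl)c3)C2=O)c1` gives 211000 nM. Compound 3 `CC(C)(C)c1ccc(CN2C(=O)S/C(=C\c3cccc(N)c3)C2=O)cc1` gives 223000 nM, a number within the scatter of that of compound 1; how the core of compound 1 and the core of compound 3 differ is not broken down here. Compound 2 `CC(C)(C)c1ccc(CN2C(=O)S/C(=C\c3ccc(N)cc3)C2=O)cc1` gives 94000 nM. Between compound 3 and compound 2 the single change is 4-aminophenyl in place of 3-aminophenyl on a double-bonded chain carbon bound to a double-bonded ring carbon, and it made a step of a 2.4-fold lower number from compound 3 to compound 2 (0.38 log units; beyond the scatter).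

Compound 4 `Nc1ccc(/C=C2\SC(=O)N(Cc3cccc(Cl)c3)C2=O)cc1` has not yet been measured. Among the measured compounds shown here, it differs from compound 1 by 4-aminophenyl in place of 3-aminophenyl on a double-bonded chain carbon bound to a double-bonded ring carbon, the same change as the one that separates compound 3 from compound 2, made here on the core of compound 1 rather than on the core of compound 3. The change appears in two places among these compounds, and only one of them has both ends measured. A single earlier step is a thin basis, and the two cores differ in a way that is not broken down here, so the expectation is held loosely and with a wide range.

For the measured compounds named here, compound 4 is expected to show a step of a 2.3-fold lower number from compound 1 to compound 4 (0.37 log units; beyond the scatter), because the one measured instance of this change gave a 2.4-fold lower number from compound 3 to compound 2 (0.38 log units; beyond the scatter). Compound 4 is therefore estimated at 90000 nM in this assay, with a range from 45000 nM to 180000 nM.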

Compound 4, half-maximal inhibitory concentration: 4700 nM
For compound 4 the middle estimate is 19-fold (1.28 log units) above the measured one; measured number outside the range, below it.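

In this assay, putting 4-aminophenyl in place of 3-aminophenyl gave a 45-fold lower number from compound 1 to compound 4 (1.65 log units; beyond the scatter), so the change lowered the number on both cores, but its size did not carry from one core to the other: the same change on two cores in this assay, a 2.4-fold lower number (0.38 log units; beyond the scatter) from compound 3 to compound 2 and a 45-fold lower number (1.65 log units; beyond the scatter) from compound 1 to compound 4, 19-fold (1.28 log units) apart, beyond the scatter of two such steps. Within these four compounds the direction of the change held on both cores, and no compound goes against it, although two pairs are a very small basis for any rule. What this does not show is which difference between the core of compound 1 and the core of compound 3 goes with the much larger step, or whether a further core would follow the smaller step, the larger one, or neither, so a step measured on one core serves here as a guide to direction at best and not to size.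

The compounds shown leave open whether the large step is specific to the core of compound 1 or recurs on other cores. They also leave open whether the amine itself matters, since they include no 4-hydroxyphenyl or 4-methoxyphenyl group in its place and no plain phenyl group on either core.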